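Adding a Methyl Group to the Core of Compound 1

This account rests on a few compounds, and the source may have more. Where it says the series, first, only, none or still open, it means among the compounds named here.

In a functional assay on T47D cells (Homo sapiens) for inhibition, read by sulforhodamine B assay, with a stated time of 48 h (a higher number here means a weaker inhibitor of growth, a lower number a stronger inhibitor of growth), compound 1 `COC(=O)[C@@]1(C)CCC=C2[C@@H]1CC[C@@H](C)[C@]2(C)Cc1c[nH]c2ccc(Cl)cc12` gives 17000 nM, the higher of the two numbers recorded. Going by the values given here, compound 2 `COC(=O)[C@@]1(C)CCC=C2[C@@H]1CC[C@@H](C)[C@]2(C)Cc1c[nH]c2ccc(F)cc12` gives 3900 nM, and the only recorded step, a 4.4-fold lower number from compound 1 to compound 2 (0.64 log units; beyond the scatter), concerns the halogen and not the position examined here. Compound 3 `COC(=O)[C@@]1(C)CCC=C2[C@@H]1CC[C@@H](C)[C@]2(C)Cc1c(C)[nH]c2ccc(Cl)cc12` differs from compound 1 by methyl in place of hydrogen on an aromatic carbon. Among the compounds with values here, no measured step bears on this change, so the account can lean on nothing beyond the scatter. The step of no change at the digits printed from compound 1 to compound 3 (within the scatter) is therefore expected to be small. Compound 3 is estimated at 17000 nM, within 5000 nM to 55000 nM.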

Compound 3, concentration for 50% growth inhibition: 17000 nM
For compound 3 middle estimate and measured number coincide at the digits printed; measured number inside the range.
By their numbers in this assay, from the lowest: compound 2; then compounds 1 and 3 (each within the scatter of the next).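

The halogen change on the shared core gave a 4.4-fold lower number from compound 1 to compound 2 (0.64 log units; beyond the scatter) in this assay but said nothing about this position. Here, methyl in place of hydrogen, on the aromatic carbon next to the ring nitrogen and next to the ring atom that bears a large group, gives no change at the digits printed from compound 1 to compound 3 (within the scatter) and so shows that this position accepts a methyl without a step beyond the scatter. Nothing on hand explains this result.

Going by these compounds, whether an ethyl chain, an amine or a carboxylic acid at this position would behave the same stays open. So does whether methyl would leave compound 2 equally unmoved.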